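The compounds below may be only part of what the source reports. "The series", "measured", "known", "first", "only" and "open" are said of these compounds alone.

In a functional assay on KB cells (Homo sapiens) for inhibition, read by sulforhodamine B assay (on this read-out higher numbers stand for weaker inhibition of growth and lower numbers for stronger inhibition of growth), three compounds that share one core and differ in a single group on an aromatic carbon have been measured. Compound 1 `Fc1ccc(-c2ccc(-c3ccc(-c4nc5ccccc5[nH]4)cc3)cc2)cc1` gives 41300 nM, compound 2 `FC(F)(F)c1ccc(-c2ccc(-c3ccc(-c4nc5ccccc5[nH]4)cc3)cc2)cc1` gives 47200 nM, and compound 3 `Oc1ccc(-c2ccc(-c3ccc(-c4nc5ccccc5[nH]4)cc3)cc2)cc1` gives 41000 nM. Compound 3 therefore cannot be separated from the other two, since all three values lie within the scatter of one another.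

Compound 4 `CN(C)c1ccc(-c2ccc(-c3ccc(-c4nc5ccccc5[nH]4)cc3)cc2)cc1` has dimethylamino in place of hydroxy on an aromatic carbon, para to a large group: dimethylamino in place of hydroxy on an aromatic carbon.

Among the compounds with values here, three measured steps bear on this change, as each exchanges the group at that same place. They are a 1.1-fold higher number from compound 1 to compound 2 (0.06 log units; within the scatter), a 1.0-fold lower number from compound 1 to compound 3 (0.00 log units; within the scatter) and a 1.2-fold lower number from compound 2 to compound 3 (0.06 log units; within the scatter). All three are within the scatter, even though fluoro, trifluoromethyl and hydroxy are different groups. Within the data shown here, none of the measured compounds carries dimethylamino, so the data say nothing directly about that group. On the evidence of these three steps, no change beyond the scatter is expected in this assay, and the expected step is a 1.1-fold lower number from compound 3 to compound 4 (0.03 log units; within the scatter). Compound 4 is estimated at 38000 nM, with an expected range from 15000 nM to 75000 nM.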

Compound 4, concentration for 50% growth inhibition: 39300 nM
Compound 4: the middle estimate sits 1.0-fold (0.01 log units) below what was measured; measured number inside the range.
By their numbers in this assay, from the lowest: compounds 4, 3, 1 and 2 (each within the scatter of the next).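

In this assay, putting dimethylamino in place of hydroxy on an aromatic carbon, para to a large group, gives a 1.0-fold lower number from compound 3 to compound 4 (0.02 log units; within the scatter). This exchange removes the only hydrogen-bond donor among the groups shown at this place and replaces 1 heavy atom with 3, yet the number stays within the scatter, so the insensitivity seen among fluoro, trifluoromethyl and hydroxy now extends to a group attached through nitrogen. The comparisons with the other two compounds agree, with a 1.2-fold lower number from compound 2 to compound 4 (0.08 log units; within the scatter) and a 1.1-fold lower number from compound 1 to compound 4 (0.02 log units; within the scatter), so none of the four groups can be separated from any other in this series, although no measurement available here bears on why the position behaves this way.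

As far as these compounds go, what remains open is whether a carboxylic acid, a primary amine or a longer alkyl chain at this place would move the number beyond the scatter, or whether this position tolerates such exchanges as well. These four compounds also differ only at this one place, so they leave open whether a change elsewhere on the shared core would alter the number in this assay.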